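This account rests on a few compounds, and the source may have more. Where it says the series, first, only, none or still open, it means among the compounds named here.

This account concerns three measured compounds and one awaiting measurement, all assessed in a functional assay (brain) for displacement of a labelled ligand, with Rattus norvegicus as the target; a higher number here means a weaker inhibitor, a lower number a stronger inhibitor. Compound 1 `CC[C@]1(c2cccc(O)c2)OC[C@H]([C@@H]2CCCCN2)O1` gives 489 nM in this assay. Compound 2 `CC[C@]1(c2ccc(O)cc2)OC[C@H]([C@@H]2CCCCN2)O1` gives 19900 nM in this assay. Compound 3 `CN1CCCC[C@H]1[C@H]1COC(c2ccccc2)(c2ccccc2)O1` gives 4400 nM in this assay, which places it second highest of the three numbers: compound 2 stands above it and compound 1 below it, each gap lying beyond the usual scatter. The unmeasured compound 4 `CCCCCCN1CCCC[C@H]1[C@H]1COC(c2ccccc2)(c2ccccc2)O1` differs from compound 3 in one place: pentyl in place of hydrogen on a saturated chain carbon bound to an amine nitrogen in a ring. Among the measured compounds shown here, no pair among the measured compounds differs in a single place, so no comparable step is available as a guide, and nothing in the measured set speaks to a change at this position. The step expected a 2.3-fold higher number from compound 3 to compound 4 (0.36 log units; beyond the scatter) is a modest one toward a higher number, though a result within the scatter would not surprise. Compound 4 is therefore estimated to give 10000 nM in this assay, with a range from 2000 nM to 50000 nM.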

Compound 4, inhibition constant: 21200 nM
The estimate for compound 4 lay 2.1-fold (0.33 log units) below the measured number, and the stated range covers the measured number.
By their numbers in this assay, from the lowest: compound 1; then compound 3; then compounds 2 and 4 (each within the scatter of the next).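

Placing pentyl on a saturated chain carbon bound to an amine nitrogen in a ring gives, in this assay, a 4.8-fold higher number from compound 3 to compound 4 (0.68 log units; beyond the scatter) and this is the only single-place step shown at this position. Read one bond further out, the same difference is methyl to hexyl, so this position is not indifferent to the chain it carries: the hexyl compound is the weaker inhibitor, yet it still gives a measurable number. Nothing available explains the size or direction of this step.

With only two chains compared, the compounds shown leave open whether the number climbs steadily with chain length or changes abruptly at some length, as an ethyl or propyl chain could tell. They also leave open whether a benzyl group, or a hexyl chain ending in an amine or a carboxylic acid, would behave as the plain hexyl chain does.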